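A few compounds are considered here, and "the series" means these few. Any claim that something is new, unique, unknown or untested is made for them only; others in the source may bear on it.

Three ureas share one core and differ only in the terminal aryl. Compound 1 `COc1cc2cc(Oc3ccc(NC(=O)Nc4ccccc4)cc3)c(C)nc2cc1OC` carries the unsubstituted phenyl; in a functional assay on SF-268 cells (Homo sapiens) for inhibition, read by sulforhodamine B assay, with a stated time of 48 h, tested at 10 uM (a higher number here means a weaker effect of the compound at the concentration tested, a lower number a stronger effect), compound 1 gives 88.1%. Compound 2 `COc1cc2cc(Oc3ccc(NC(=O)Nc4ccc(C)cc4)cc3)c(C)nc2cc1OC` gives 80.2%, the step being a number 7.9 percentage points lower from compound 1 to compound 2 (within the scatter). Compound 3 `COc1cc2cc(Oc3ccc(NC(=O)Nc4ccc(C(F)(F)F)cc4)cc3)c(C)nc2cc1OC` gives 79.3%, with a number 8.8 percentage points lower from compound 1 to compound 3 (within the scatter) and a number 0.9 percentage points lower from compound 2 to compound 3 (within the scatter). Compound 3 thus holds the lowest of the three numbers, but each step leading to it lies within the scatter, so no order among the three compounds can be claimed from these data.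

Compound 4 `COc1cc2cc(Oc3ccc(NC(=O)Nc4cccc(C(F)(F)F)c4)cc3)c(C)nc2cc1OC` is not yet measured. It differs from compound 3 by 3-(trifluoromethyl)phenyl in place of 4-(trifluoromethyl)phenyl on an amide-type nitrogen. For the measured compounds named here, none of the measured steps is of this kind; each of them exchanges one group at one aromatic carbon, and each, a number 7.9 percentage points lower from compound 1 to compound 2 (within the scatter), a number 8.8 percentage points lower from compound 1 to compound 3 (within the scatter) and a number 0.9 percentage points lower from compound 2 to compound 3 (within the scatter), stayed within the scatter. The three measured numbers therefore give no ground to expect a step beyond the scatter in this assay in either direction. For compound 4 the estimate in this assay is 80%, between 65% and 92%, which means an expected step of a number 0.7 percentage points higher from compound 3 to compound 4 (within the scatter).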

Compound 4, a percentage reported as activity, at one concentration (the size of the read-out at that concentration, not a potency): 29.2%
The estimate for compound 4 lay 50.8 percentage points above the measured number, and the stated range ends above it.
By their numbers in this assay, from the lowest: compound 4; then compounds 3, 2 and 1 (each within the scatter of the next).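

Compound 4 and compound 3 carry the same atoms, yet 3-(trifluoromethyl)phenyl in place of 4-(trifluoromethyl)phenyl on the amide-type nitrogen gives in this assay a number 50.1 percentage points lower from compound 3 to compound 4 (beyond the scatter). The terminal aryl is therefore not indifferent to change, as the three earlier compounds alone suggested: where the trifluoromethyl stands on this ring decides the outcome here, with a number 58.9 percentage points lower from compound 1 to compound 4 (beyond the scatter) against the unsubstituted phenyl and a number 51 percentage points lower from compound 2 to compound 4 (beyond the scatter) against 4-methylphenyl. Nothing measured on these compounds accounts for the size of this change.

Open, from the compounds shown here alone, is whether the large step belongs to trifluoromethyl itself or to any group placed where compound 4 carries it, such as a methyl, a chlorine or a methoxy. Also open, going by these compounds, is whether a second such group on the same ring, for instance a fluorine, keeps the step.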